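Ether chain of compound 1: ethoxy to allyloxy

This account rests on a few compounds, and the source may have more. Where it says the series, first, only, none or still open, it means among the compounds named here.

Working notes on the series of compound 1 `CCOc1ccc(-c2c(C#N)c(N)nc(SCc3ccn[nH]3)c2C#N)cc1`. In an assay on CHO cells for displacement of a labelled ligand from adenosine receptor A1 (Homo sapiens), read by scintillation counting, with a stated time of 90 min (on this read-out higher numbers stand for weaker inhibition and lower numbers for stronger inhibition), compound 1 gives 21 nM, the lowest of the three numbers measured. Compound 2 `COC(=O)c1cccc(CSc2nc(N)c(C#N)c(-c3ccc(OCC4CC4)cc3)c2C#N)c1` gives 66 nM in this assay; compound 3 `CCOc1ccc(-c2c(C#N)c(N)nc(SCC(N)=O)c2C#N)cc1` gives 345 nM. Going by the values given here, the one step measured within a single site, a 16-fold higher number from compound 1 to compound 3 (1.22 log units; beyond the scatter), concerns the group on a saturated chain carbon bound to a sulfur, not the ether.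

Compound 4 `C=CCOc1ccc(-c2c(C#N)c(N)nc(SCc3ccn[nH]3)c2C#N)cc1` differs from compound 1 by vinyl in place of methyl on a saturated chain carbon bound to an oxygen on an aromatic ring. Among the compounds with values here, no measured step changes this position alone: compound 2 carries a different ether but also a different thioether, so its value and that of compound 1 show only the combined outcome of two changes. The ether side of the core is thus untested by any single step. With the sulfur side unchanged, and the difference confined to one carbon of the ether chain, the expected step of a 1.2-fold higher number from compound 1 to compound 4 (0.08 log units; within the scatter) is none beyond the scatter. Compound 4 is therefore expected to give about 25 nM in this assay, in the range 8 nM to 75 nM.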

Compound 4, inhibition constant: 44 nM
Beside the measured number, compound 4's estimate is 1.8-fold (0.25 log units) below it; the range from low to high includes it.
By their numbers in this assay, from the lowest: compound 1; then compounds 4 and 2 (each within the scatter of the next); then compound 3.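

On the ether side of the core, the change from ethoxy to allyloxy now gives a single-site reading in this assay: a 2.1-fold higher number from compound 1 to compound 4 (0.32 log units; beyond the scatter). This shows that the position responds to a change confined to the ether chain, with the sulfur side held constant. The step is modest, whereas the step on the sulfur side, a 16-fold higher number from compound 1 to compound 3 (1.22 log units; beyond the scatter), is large, and no measurement at hand accounts for the ether step.

The compounds shown leave open whether the higher number goes with the double bond of the allyl group or with the chain extension itself, a question that a saturated propoxy chain would address. They also leave open how a hydroxyl or an amine at the end of the ether chain would read with the sulfur side unchanged.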